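From 2-chlorobenzyl to 3-fluorobenzyl on a shared core

This account rests on a few compounds, and the source may have more. Where it says the series, first, only, none or still open, it means among the compounds named here.

Compound 1 `CCOC(=O)c1ccc(-c2nn(Cc3ccccc3Cl)c3ccccc23)cc1` sits at the edge of what a functional assay on cells (Platelet, Homo sapiens) for inhibition (on this read-out higher numbers stand for weaker inhibition and lower numbers for stronger inhibition), can read. In this assay compound 1 gives > 10000 nM, which is a limit and not a number. Compound 2 `CCOC(=O)c1ccc(-c2nn(Cc3ccc(Cl)cc3)c3ccccc23)cc1` gives > 10000 nM, and this too is a limit. The record so far is therefore (the limit of > 10000 nM in this assay, at which 2 of the 2 values shown sit). Within the data shown here, the only measured step is a step that the two limits leave unreadable from compound 1 to compound 2, with 4-chlorophenyl in place of 2-chlorophenyl, so it offers no size to carry forward.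

Compound 3 `CCOC(=O)c1ccc(-c2nn(Cc3cccc(F)c3)c3ccccc23)cc1` changes the same place: 3-fluorophenyl in place of 2-chlorophenyl on a saturated chain carbon bound to an aromatic nitrogen. In words, this is 3-fluorophenyl in place of 2-chlorophenyl on a saturated chain carbon bound to an aromatic nitrogen. Neither the size nor the direction of this change can be read from the data. On the reading of compound 1, whose limit is > 10000 nM, compound 3 is expected to remain weak, and it may well report only a limit. The estimated value for compound 3 is 8000 nM, with an expected range of 1000 nM to 30000 nM. The expected step is an at least 1.2-fold lower number from compound 1 to compound 3 (0.09 log units; that floor lies within the scatter).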

Compound 3, half-maximal inhibitory concentration: > 10000 nM
Compound 3 gave a limit, no number; the forecaster's own chance of this, stated with the estimate: 50%; at least 1.2-fold (0.09 log units) between middle value and limit.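

Compound 3 ends at a limit in this assay, as compound 1 and compound 2 do, so no step among these three compounds can be read. The compounds shown leave open how 2-chlorophenyl, 4-chlorophenyl and 3-fluorophenyl rank at this place, and whether any of them gives a measurable inhibition: the limit of > 10000 nM in this assay, at which 3 of the 3 values shown sit.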